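A few compounds are considered here, and "the series" means these few. Any claim that something is new, unique, unknown or untested is made for them only; others in the source may bear on it.

Measured compounds:
compound 1 `O=C(O)CC[C@H](NC(=O)[C@]1(O)C[C@@H](O)[C@@H](O)[C@H](O)C1)C(=O)O`: 21000000 nM
compound 2 `C[C@H](NC(=O)[C@]1(O)C[C@@H](O)[C@@H](O)[C@H](O)C1)C(=O)O`: a limit, > 50000000 nM
compound 3 `CCC(C)[C@H](NC(=O)[C@]1(O)C[C@@H](O)[C@@H](O)[C@H](O)C1)C(=O)O`: 19000000 nM

All three share one core and differ only in the group on the saturated chain carbon bound to an amide-type nitrogen and a carbonyl carbon. In an assay on HL-60 cells for inhibition of P-selectin (Homo sapiens) (on this read-out lower numbers stand for stronger inhibition and higher numbers for weaker inhibition), compound 1 gives 21000000 nM. For compound 2 this assay reports only a limit, > 50000000 nM (the limit of > 50000000 nM in this assay, at which 1 of the 3 values shown sits). Compound 3 gives 19000000 nM in this assay, the lowest of the two plain numbers, although a 1.1-fold lower number from compound 1 to compound 3 (0.04 log units; within the scatter) lies within the scatter. Among the measured compounds shown here, the one clear step is an at least 2.6-fold lower number from compound 2 to compound 3 (0.42 log units; beyond the scatter), which shows that a small group in this place gives a weaker result than sec-butyl.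

Compound 4 `O=C(O)[C@H](CO)NC(=O)[C@]1(O)C[C@@H](O)[C@@H](O)[C@H](O)C1` carries hydroxymethyl in place of sec-butyl on a saturated chain carbon bound to an amide-type nitrogen and a carbonyl carbon. Hydroxymethyl is again a small group, so this change resembles a reversal of an at least 2.6-fold lower number from compound 2 to compound 3 (0.42 log units; beyond the scatter), and a modest rise in the number is expected, with a real chance that this assay again returns only a limit. The expected step is a 2.4-fold higher number from compound 3 to compound 4 (0.37 log units; beyond the scatter). Compound 4 is therefore estimated at 45000000 nM, between 15000000 nM and 120000000 nM.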

Compound 4, half-maximal inhibitory concentration: 19500000 nM
For compound 4 the middle estimate is 2.3-fold (0.36 log units) above the measured one; the range from low to high includes it.
By their numbers in this assay, from the lowest: compounds 3, 4 and 1 (each within the scatter of the next). At a limit, above all of these: compound 2.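

In this assay, hydroxymethyl and sec-butyl cannot be told apart at this position: a 1.0-fold higher number from compound 3 to compound 4 (0.01 log units; within the scatter), even though hydroxymethyl has fewer heavy atoms and adds a hydrogen-bond donor and acceptor. The 2-carboxyethyl group cannot be separated from hydroxymethyl either: a 1.1-fold lower number from compound 1 to compound 4 (0.03 log units; within the scatter). The earlier reading that a small group here gives a weaker result therefore fails for hydroxymethyl: an at least 2.5-fold lower number from compound 2 to compound 4 (0.40 log units; beyond the scatter), a step that rests on compound 2 having only a limit.

The compounds shown leave open whether a longer chain ending in an amine, or a phenyl ring, on this saturated chain carbon would give a number clearly different from those of compound 1, compound 3 and compound 4. They also do not show whether methyl's result stands alone among small groups, as ethyl would help to test.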